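Working notes: a methyl step on compound 2

The source may report more compounds than this note shows. Statements on the series, on what has been measured and on what is new or still open speak of the compounds shown alone.

Of the compounds shown here, two have been read so far in a toxicity assay on MT4 cells (Homo sapiens) for cytotoxicity, read by MTT assay, with a stated time of 5 days; on this read-out higher numbers stand for lower toxicity in this test and lower numbers for higher toxicity in this test. Compound 1 (`Cc1cnc(Nc2ccc(C#N)cc2)nc1Nc1c(F)cc(-c2cc(F)nc(F)c2)cc1F`) gives 103000 nM. Compound 2 (`Cc1cc(-c2cccs2)cc(C)c1Nc1ccnc(Nc2ccc(C#N)cc2)n1`) gives 10000 nM, the lower of the two numbers, and its gap to compound 1 lies beyond the usual scatter. Within the data shown here, no measured pair differing in one place is available, so the next step has no direct precedent.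

Compound 3 (`Cc1csc(-c2cc(C)c(Nc3ccnc(Nc4ccc(C#N)cc4)n3)c(C)c2)c1`) comes from compound 2 by one change: methyl in place of hydrogen on an aromatic carbon. This is methyl in place of hydrogen on an aromatic carbon, or thiophen-2-yl to 4-methylthiophen-2-yl. The data do not show what this change does in this assay. Starting from compound 2 at 10000 nM, a single added methyl is expected to leave the number within the scatter, with only a slight lean towards lower numbers. The expected change is small, shown as a 1.3-fold lower number from compound 2 to compound 3 (0.10 log units; within the scatter). The estimate for compound 3 is 8000 nM, with an expected range of 3000 nM to 25000 nM.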

Compound 3, half-maximal cytotoxic concentration: 34000 nM
Estimate against measurement, compound 3: 4.3-fold (0.63 log units) below, and the stated range ends below it.
By their numbers in this assay, from the lowest: compound 2; then compound 3; then compound 1.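

In this assay, methyl in place of hydrogen on an aromatic carbon gives a 3.4-fold higher number from compound 2 to compound 3 (0.53 log units; beyond the scatter), so this place on the five-membered aromatic ring with 1 sulfur, two ring bonds from the ring sulfur and two ring bonds from the ring atom that bears a large group, responds to a single added carbon. Among these compounds, this is the only step between measured compounds that differ in one place, and it moves the number upward, so thiophen-2-yl to 4-methylthiophen-2-yl counts as a real if modest change in this test. It rests on one pair, however, and so describes this change on the core of compound 2 rather than any general effect of methyl, and no supporting data bear on why the number moves.

As far as these compounds go, it remains open whether an ethyl chain, an amine or a carboxylic acid at this same place would move the number further upward, leave it unchanged or reverse the step. Also open, from the compounds shown here alone, is whether a methyl on the other carbons of the thiophene ring would give a step of similar size.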